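Naphthol Amide Series: From Propanoylamino to Dimethylamino

This account rests on a few compounds, and the source may have more. Where it says the series, first, only, none or still open, it means among the compounds named here.

Compound 1, `NC(=O)c1ccc(O)c2ccccc12`: compound 1 gives "not determined" (no result reported) in an assay on isolated protein for inhibition of histone acetyltransferase p300 (Homo sapiens), read by fluorescence, with a stated time of 5 min, in the presence of a further agent that is not named here; on this read-out lower numbers stand for stronger inhibition and higher numbers for weaker inhibition.
Compound 2, `CCCCCCCCCC(=O)Nc1ccc(O)c2ccccc12`: compound 2 gives 60000 nM in this assay.
Compound 3, `CCC(=O)Nc1ccc(O)c2ccccc12`: compound 3 gives "not determined" (no result reported) in this assay.

Compound 3 therefore has no number of its own in this assay, and compound 1 is in the same position, so only compound 2 offers a measured value, and that value shows weak inhibition. Compound 4, `CN(C)c1ccc(O)c2ccccc12`, differs from compound 3 in one place: dimethylamino in place of propanoylamino on an aromatic carbon. Within the data shown here, no step between measured compounds exists to anchor this change, so no direction can be read from the data. Given the weak value of compound 2 in this assay, compound 4 is expected to stay in the weak range at about 60000 nM, between 10000 nM and 300000 nM.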

Compound 4, half-maximal inhibitory concentration: 3700 nM
Estimate against measurement, compound 4: 16-fold (1.21 log units) above; the measured number lies below the stated range.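

Among these compounds, compound 3 has no single number in this assay, so no step to compound 4 can be read. On these data alone, what dimethylamino in place of propanoylamino does to inhibition stays open, and no evidence bears on it.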